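A Fluorine Added to a Pair of Inactive Pyridazinone Amides

A few compounds are considered here, and "the series" means these few. Any claim that something is new, unique, unknown or untested is made for them only; others in the source may bear on it.

Compound 1, `COc1ccc(-n2ccc(=O)c(C(=O)Nc3ccc(Oc4ccnc5c4ccn5C)cc3)n2)cc1`, gives > 60000 nM in a functional assay on HepG2 cells (Homo sapiens) for cytotoxicity, read by MTT assay, with a stated time of 72 h; a higher number here means a weaker inhibitor, a lower number a stronger inhibitor. That value is a limit of the assay, not a number.
Compound 2, `Cn1ccc2c(Oc3ccc(NC(=O)c4nn(-c5ccc(Cl)c(F)c5)ccc4=O)cc3)ccnc21`, gives > 60000 nM in this assay. That value is also a limit of the assay, not a number.

Among the measured compounds shown here, compound 1 therefore stands only at a limit in this assay, and the one further value shown is a limit as well. For the measured compounds named here, the single step between the measured compounds, a step that the two limits leave unreadable from compound 1 to compound 2, cannot be read, since both ends sit at the limit, as the limit of > 60000 nM in this assay, at which 2 of the 2 values shown sit, records. Compound 3, `COc1ccc(-n2ccc(=O)c(C(=O)Nc3ccc(Oc4ccnc5c4ccn5C)c(F)c3)n2)cc1`, differs from compound 1 by fluoro in place of hydrogen on an aromatic carbon, ortho to a large group and meta to a large group. No measured step bears on this change, and the one step shown gives no size at all. The expectation for compound 3 is thus a step of a number no higher from compound 1 to compound 3 (the limit leaves the size open) of no size beyond the scatter, with compound 3 most likely remaining at the limit in this assay. Compound 3 is expected at 60000 nM, within a range from 30000 nM to 120000 nM.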

Compound 3, half-maximal inhibitory concentration: > 60000 nM
Compound 3 ended at the assay's limit (the forecaster's own chance of this, stated with the estimate: 85%); the middle value sits exactly at the limit.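

The step from compound 1 to compound 3 cannot be read, and no other new step can be read either, since both compounds stand at the same limit: the limit of > 60000 nM in this assay, at which 3 of the 3 values shown sit.
In this assay the compounds shown leave open how far compound 1, compound 2 and compound 3 each lie beyond that limit, and whether either change alters cytotoxicity at all.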